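A Sulfo Ester Joins a Level Series

The source may report more compounds than this note shows. Statements on the series, on what has been measured and on what is new or still open speak of the compounds shown alone.

In a functional assay on HepG2 cells (Homo sapiens) for inhibition, read by MTT assay, with a stated time of 3 days (a lower number here means a stronger inhibitor, a higher number a weaker inhibitor), compound 1 (`COc1cc(-c2nc3ccccc3s2)ccc1OCC(=O)NNC(=O)CN(C(C)=O)[C@@H](CS)C(=O)O`) gives 3420 nM, compound 2 (`COc1cc(-c2nc3ccccc3s2)ccc1OCC(=O)NNC(=O)CN1CCC[C@H]1C(=O)O`) gives 2650 nM and compound 3 (`CCOC(=O)CN(C)CC(=O)NNC(=O)COc1ccc(-c2nc3ccccc3s2)cc1OC`) gives 3180 nM, so compound 3 stands level with the other two. Compound 4 (`CCOC(=O)[C@H](CS(=O)(=O)O)NCC(=O)NNC(=O)COc1ccc(-c2nc3ccccc3s2)cc1OC`) alters compound 3 in one place: (1-(ethoxycarbonyl)-2-sulfoethyl)amino in place of ((ethoxycarbonyl)methyl)(methyl)amino on a saturated chain carbon bound to a carbonyl carbon. Three measured steps exchange groups at that same place: a 1.3-fold lower number from compound 1 to compound 2 (0.11 log units; within the scatter), a 1.1-fold lower number from compound 1 to compound 3 (0.03 log units; within the scatter) and a 1.2-fold higher number from compound 2 to compound 3 (0.08 log units; within the scatter), all within the scatter. Among the compounds with values here, none of the measured compounds carries the sulfo group, so the evidence is indirect and the range stays wide. The expected step is a 1.1-fold lower number from compound 3 to compound 4 (0.03 log units; within the scatter), no larger than the scatter. For compound 4 the estimate is 3000 nM, with an expected range of 1400 nM to 6500 nM.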

Compound 4, half-maximal inhibitory concentration: 3360 nM
For compound 4 the middle estimate is 1.1-fold (0.05 log units) below the measured one; the measured number falls inside the stated range.
By their numbers in this assay, from the lowest: compounds 2, 3, 4 and 1 (each within the scatter of the next).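

Within the data shown here, the (1-(ethoxycarbonyl)-2-sulfoethyl)amino group brings a sulfo group to this place for the first time, and in this assay all three new comparisons stay within the scatter (a 1.1-fold higher number from compound 3 to compound 4 (0.02 log units; within the scatter)) (a 1.3-fold higher number from compound 2 to compound 4 (0.10 log units; within the scatter)) (a 1.0-fold lower number from compound 1 to compound 4 (0.01 log units; within the scatter)). On this saturated chain carbon bound to a carbonyl carbon, four different groups, now including a sulfo-bearing one, give numbers that cannot be told apart. Nothing available explains this result.

The compounds shown leave open whether a plain primary amine or a long unbranched carbon chain at this place would also leave the number level. They also leave open whether any group here can shift it beyond the scatter.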